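This account rests on a few compounds, and the source may have more. Where it says the series, first, only, none or still open, it means among the compounds named here.

Compound 1 `Cc1ccsc1C(=O)OC(CCN(C)C)c1ccc(Cl)cc1` gives 119% in an assay on NIH3T3 cells with Urotensin-2 receptor (Homo sapiens) as the target; a lower number here means a smaller maximal response, a higher number a larger maximal response.
Compound 2 `CCc1ccccc1C(=O)OC(CCN(C)C)c1ccc(Cl)cc1` gives 128% in this assay.

Within the data shown here, compound 2 stands with compound 1 within the usual scatter: the only measured step, a number 9 percentage points higher from compound 1 to compound 2 (within the scatter), is too small to count. Compound 3 `Cc1ccc(C)c(C(=O)OC(CCN(C)C)c2ccc(Cl)cc2)c1` differs from compound 2 by 2,5-dimethylphenyl in place of 2-ethylphenyl on a carbonyl carbon. Among the measured compounds shown here, no measured step swaps one aromatic group of the same atoms for another, so the step from compound 1 bears only loosely on it. A change beyond the scatter is therefore not expected, and the step of a number 6 percentage points lower from compound 2 to compound 3 (within the scatter) is estimated to be small. Compound 3 is expected to give about 122%, between 100% and 142%.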

Compound 3, largest response reached (reported as efficacy), in percent of the reference or control that the assay uses: 86%
Compound 3: the middle estimate sits 36 percentage points above what was measured, and the stated range ends above it.
By their numbers in this assay, from the lowest: compound 3; then compounds 1 and 2 (each within the scatter of the next).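

On the carbonyl carbon, the same eight carbon atoms arranged differently do not give the same maximal response: 2,5-dimethylphenyl in place of 2-ethylphenyl gives a number 42 percentage points lower from compound 2 to compound 3 (beyond the scatter) in this assay, so this position responds to how the ring is substituted and not only to its atom count. 2,5-dimethylphenyl in place of 3-methylthiophen-2-yl is also a large change, a number 33 percentage points lower from compound 1 to compound 3 (beyond the scatter), unlike the earlier step. Nothing available explains why the response falls. The compounds shown leave open how an unsubstituted phenyl, or a phenyl ring carrying a methoxy group or an amine, would behave at this place.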